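The source may hold more compounds than are shown below. What is called first, only, known or untested is meant among the compounds shown, and "the series" means these compounds.

Measured compounds in an ADME assay on MRC5 cells (Homo sapiens) for cytotoxicity, read by fluorescence, with a stated time of 72 h; on this read-out lower numbers stand for stronger inhibition and higher numbers for weaker inhibition:

Compound 1 `O=[N+]([O-])c1cn2c(n1)OC(COc1ccc(-c3ccc(F)cc3)cc1)C2`: a limit, > 64000 nM.
Compound 2 `O=[N+]([O-])c1cn2c(n1)OC(COc1ccc(-c3ccc(C(F)(F)F)cc3)cc1)C2`: a limit, > 64000 nM.
Compound 3 `O=[N+]([O-])c1cn2c(n1)OC(COc1ccc(-c3ccc(F)cc3)nc1)C2`: a limit, > 64000 nM.

All three values are limits of this assay, not numbers. The change from compound 1 to compound 2 is trifluoromethyl in place of fluoro on an aromatic carbon; the step it made, a step that the two limits leave unreadable from compound 1 to compound 2, cannot be read, because both ends sit at a limit of this assay. The difference between the core of compound 1 and the core of compound 3 is not broken down here. Compound 4 `O=[N+]([O-])c1cn2c(n1)OC(COc1ccc(-c3ccc(C(F)(F)F)cc3)nc1)C2` is not yet measured; it differs from compound 3 by trifluoromethyl in place of fluoro on an aromatic carbon, the same change as that from compound 1 to compound 2.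

Within the data shown here, for the step from compound 3 to compound 4 in this assay, the expectation rests on the limit of > 64000 nM in this assay, at which 3 of the 3 values shown sit: every value so far is a limit, and the one comparable change gave a step that could not be read. Compound 4 is therefore expected to give a step that the limit leaves unreadable from compound 3 to compound 4, most likely again only a limit. The estimate for compound 4 is 100000 nM, with a range from 40000 nM to 400000 nM.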

Compound 4, half-maximal inhibitory concentration: > 64000 nM
Compound 4 gave a limit, no number; the forecaster's own chance of this, stated with the estimate: 85%; the middle value does not contradict the limit.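

In this assay compound 4 gives > 64000 nM, a limit and not a number. No new step can be read from compound 3 to compound 4, as both ends sit at the same limit: the limit of > 64000 nM in this assay, at which 4 of the 4 values shown sit.

The compounds shown leave open whether trifluoromethyl in place of fluoro shifts the value in this assay at all, on either core.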